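The source may hold more compounds than are shown below. What is called first, only, known or untested is meant among the compounds shown, and "the series" means these compounds.

Measured so far in a functional assay on PC-3 cells (Homo sapiens) for antiproliferative activity, read by MTT assay, tested at 1 uM; a higher number here means a stronger effect of the compound at the concentration tested, a lower number a weaker effect:

Compound 1, `COc1cc(C2=NN(C(C)=O)C(c3cccc(OC)c3OC)O2)cc(OC)c1OC`, gives 35%.
Compound 2, `COc1ccc(OC)c(C2OC(c3cc(OC)c(OC)c(OC)c3)=NN2C(C)=O)c1`, gives 37.2%.

Within the data shown here, compound 2 and compound 1 sit within the usual scatter of each other, the only difference being a number 2.2 percentage points higher from compound 1 to compound 2 (within the scatter). On these two numbers compound 2 therefore stands level with compound 1 rather than apart from it.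

Compound 3, `COc1cc(C2=NN(C(C)=O)C(c3ccc(F)cc3)O2)cc(OC)c1OC`, has not yet been tested in this assay. It differs from compound 2 in one place: 4-fluorophenyl in place of 2,5-dimethoxyphenyl on a saturated ring carbon. Among the measured compounds shown here, the only measured step, from compound 1 to compound 2, exchanged one dimethoxyphenyl for another and stayed within the scatter; it says little about replacing both methoxy groups with a single fluorine. With no closer guide, a change beyond the scatter is not expected, and compound 3 is estimated at 32%, between 15% and 50%, a step of a number 5.2 percentage points lower from compound 2 to compound 3 (within the scatter).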

Compound 3, a percentage reported as inhibition, at one concentration (the size of the read-out at that concentration, not a potency): 0%
Estimate against measurement, compound 3: 32 percentage points above; the whole stated range lies above it.
By their numbers in this assay, from the lowest: compound 3; then compounds 1 and 2 (each within the scatter of the next).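

In this assay, 4-fluorophenyl in place of 2,5-dimethoxyphenyl gives a number 37.2 percentage points lower from compound 2 to compound 3 (beyond the scatter), and 4-fluorophenyl in place of 2,3-dimethoxyphenyl gives a number 35 percentage points lower from compound 1 to compound 3 (beyond the scatter). The earlier step exchanged only one dimethoxyphenyl for another and stayed within the scatter, whereas these two show that the group on this saturated ring carbon can decide whether any effect is seen at the tested concentration. Nothing available explains this drop.

This change removes both methoxy groups and adds a fluorine at once, so the compounds shown cannot separate the effect of losing the methoxy groups from that of gaining the fluorine. Plain phenyl and 4-methoxyphenyl at this position would be the closest comparisons, and how either would behave remains open.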